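The compounds below may be only part of what the source reports. "The series", "measured", "known", "first", "only" and "open" are said of these compounds alone.

Measured so far in an ADME assay on L1210/0 cells (Mus musculus) for cytotoxicity, with a stated time of 48 h; a higher number here means a weaker inhibitor, a lower number a stronger inhibitor:

Compound 1 `O[C@H]1C[C@@H](Cn2cnc3c(-c4ccccc4)ncnc32)c2ccccc21`: > 200000 nM (a limit of the assay)
Compound 2 `O=C1O/C(=C\Cn2cc(Br)c(=O)[nH]c2=O)C(OCc2ccccc2)=C1OCc1ccccc1`: 7500 nM

Among the measured compounds shown here, compound 2 stands alone here, with 7500 nM as the only actual number in this assay. Compound 1 has only a limit, > 200000 nM. For the measured compounds named here, the two measured compounds do not form a single-place pair, so no measured step shows how a change in one place plays out.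

Compound 3 `O=C1O/C(=C\Cn2ccc(=O)[nH]c2=O)C(OCc2ccccc2)=C1OCc1ccccc1` keeps the structure of compound 2 except for one site, where hydrogen stands in place of bromo on an aromatic carbon (hydrogen in place of bromo on an aromatic carbon). With so small a change, a modest shift towards weaker inhibition is expected, though this is only a cautious guess. The estimated change is a 2.0-fold higher number from compound 2 to compound 3 (0.30 log units; within the scatter). For compound 3 the expected value is 15000 nM, with an estimated range of 4000 nM to 70000 nM.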

Compound 3, half-maximal inhibitory concentration: 12900 nM
Compound 3: middle estimate off by 1.2-fold (0.07 log units), on the high side; the range from low to high includes it.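

Among the compounds shown here, this is the first pair here that differs in one place, and in this assay it gives a 1.7-fold higher number from compound 2 to compound 3 (0.24 log units; within the scatter) for hydrogen in place of bromo on an aromatic carbon of the six-membered aromatic ring with 2 nitrogen. The two compounds cannot be told apart in this read-out, so the bromo group at this position is not needed for the inhibition seen with compound 2, and the shared core still inhibits without it. Nothing measured in the data shown bears on why this swap reads as it does.

As far as these compounds go, only bromo and hydrogen appear at this carbon, so it remains open whether an amine, a carboxylic acid or a longer chain there would read the same. A single pair also cannot show which other parts of the shared core the inhibition depends on.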